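Nitro to trifluoromethyl on a thiourea aryl ring

The source may report more compounds than this note shows. Statements on the series, on what has been measured and on what is new or still open speak of the compounds shown alone.

Measured so far in an assay on isolated protein for binding affinity to stress-70 protein, mitochondrial (Homo sapiens); on this read-out higher numbers stand for weaker binding and lower numbers for tighter binding:
compound 1 `CC1(C)CCNc2ccc(NC(=O)Nc3ccc([N+](=O)[O-])cc3)cc21`: 1100 nM
compound 2 `CC1(C)CCNc2ccc(NC(=S)Nc3ccc([N+](=O)[O-])cc3)cc21`: 1600 nM

On these two numbers compound 2 sits at the upper end, and compound 1 lies within the usual scatter of it, so the two cannot be told apart. The next compound is compound 3 `CC1(C)CCNc2ccc(NC(=S)Nc3ccc(C(F)(F)F)cc3)cc21`, which differs from compound 2 by trifluoromethyl in place of nitro on an aromatic carbon. Within the data shown here, no measured pair shows this change, so nothing indicates its size or direction; a step within the scatter is expected, no change at the digits printed from compound 2 to compound 3 (within the scatter). Compound 3 is therefore estimated at 1600 nM, with a range from 500 nM to 5000 nM.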

Compound 3, dissociation constant: 3300 nM
Compound 3: middle estimate off by 2.1-fold (0.31 log units), on the low side, within the range that was stated.
By their numbers in this assay, from the lowest: compounds 1 and 2 (each within the scatter of the next); then compound 3.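

In this assay, trifluoromethyl in place of nitro on this aromatic carbon, para to a large group, gives a 2.1-fold higher number from compound 2 to compound 3 (0.31 log units; beyond the scatter) and so weakens binding modestly. Among these compounds, this is the first sign that binding responds to the group at this position, and here nitro is the better of the two on the thiourea. No measurement available accounts for the step. Going by these compounds, whether a nitrile, an amine or a carboxylic acid here would match nitro remains open, as does whether the same change would act alike on the carbonyl analogue, compound 1.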